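This account rests on a few compounds, and the source may have more. Where it says the series, first, only, none or still open, it means among the compounds named here.

In a functional assay on UACC-257 cells (Homo sapiens) for inhibition, read by sulforhodamine B assay, with a stated time of 48 h (a higher number here means that more compound is tolerated, a lower number that less compound is tolerated), compound 1 `Nc1cc(N)c2nc(-c3ccccc3)c(NCc3ccc(F)cc3)nc2c1` gives 8910 nM. For compound 2 `COc1ccc(Sc2nc3cc(N)cc(N)c3nc2-c2ccccc2)cc1` this assay reports only a limit, < 100000 nM. The step that the limit leaves unreadable from compound 1 to compound 2 is therefore not readable, as the limit of < 100000 nM in this assay, at which 1 of the 2 values shown sits, shows. Compound 3 `Nc1cc(N)c2nc(-c3ccccc3)c(Sc3ccc(Cl)c(Cl)c3)nc2c1` differs from compound 2 by 3,4-dichlorophenyl in place of 4-methoxyphenyl on a sulfur. Going by the values given here, no measured step bears on this change, and compound 2 stands only at a limit in this assay, so nothing sets a direction. The step that the limit leaves unreadable from compound 2 to compound 3 is expected to lie within the scatter. Compound 3 is estimated at 20000 nM in this assay, with a range from 3000 nM to 100000 nM.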

Compound 3, concentration lethal to 50% of the cells: < 100000 nM
Compound 3 gave a limit, no number; the forecaster's own chance of this, stated with the estimate: 30%; the middle value lies beyond the limit too.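

In this assay compound 3 gives only a limit, < 100000 nM. No step linking compound 1, compound 2 and compound 3 can be read: the limit of < 100000 nM in this assay, at which 2 of the 3 values shown sit.

Still open, from the compounds shown here alone, is how 3,4-dichlorophenyl compares with 4-methoxyphenyl on the sulfur, and how either sulfanyl group compares with the (4-fluorobenzyl)amino group of compound 1.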